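From 4-methylphenyl to 3,5-dimethylphenyl on a sulfur

The source may report more compounds than this note shows. Statements on the series, on what has been measured and on what is new or still open speak of the compounds shown alone.

Measured in a functional assay on HeLa cells (Homo sapiens) for inhibition, read by CCK-8 assay, with a stated time of 72 h, tested at 2 uM; a higher number here means more inhibition of growth at the concentration tested, a lower number less inhibition of growth:
compound 1 `Nc1ccccc1NC(=O)/C=C/c1ccc(CSc2ccc(Cl)cc2)cc1`: 1.94%
compound 2 `CCc1ccc(SCc2ccc(/C=C/C(=O)Nc3ccccc3N)cc2)cc1`: 3.96%
compound 3 `Cc1ccc(SCc2ccc(C(=O)Nc3ccccc3N)cc2)cc1`: 33.8%

Compound 3 stands highest of the three at 33.8%, and its gaps to compound 1 and compound 2 both lie beyond the scatter. The next compound, compound 4 `Cc1cc(C)cc(SCc2ccc(C(=O)Nc3ccccc3N)cc2)c1`, has not yet been measured. It keeps the rest of compound 3 and changes one group: 3,5-dimethylphenyl in place of 4-methylphenyl on a sulfur. In words, 3,5-dimethylphenyl stands in place of 4-methylphenyl on a sulfur.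

Among the measured compounds shown here, only one measured step bears on a swap of this kind. It is a number 2 percentage points higher from compound 1 to compound 2 (within the scatter), with ethyl in place of chloro on an aromatic carbon. For the measured compounds named here, that step is small, but it is a weak guide, as it comes from a pair with low values and no measured step starts at compound 3. On this evidence, no step beyond the scatter is expected in this assay, and neither direction is clearly favoured. The estimate corresponds to an expected a number 3.8 percentage points lower from compound 3 to compound 4 (within the scatter). The uncertainty remains wide, since a single step is all the data offer. For compound 4 the expected value is 30%, with an estimated range of 12% to 52%.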

Compound 4, percent growth inhibition at one concentration: 40.2%
For compound 4 the middle estimate is 10.2 percentage points below the measured one; the range from low to high includes it.
By their numbers in this assay, from the lowest: compounds 1 and 2 (each within the scatter of the next); then compounds 3 and 4 (each within the scatter of the next).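

In this assay, 3,5-dimethylphenyl in place of 4-methylphenyl on a sulfur gives a number 6.4 percentage points higher from compound 3 to compound 4 (within the scatter), and this is the first step shown that starts from compound 3 rather than from a pair with low values. It shows that, on a sulfur whose other neighbour is a saturated chain carbon, a group of 8 heavy atoms can stand in place of one of 7 with no change beyond the scatter, so compound 3 and compound 4 cannot be told apart in this read-out. No measurement shown gives a reason for this result.

The compounds shown leave open whether a step beyond the scatter can be reached at this place with a different group on the aromatic ring, such as a methoxy group or an amine. Among the compounds shown here, they also leave open whether 3,5-dimethylphenyl on the sulfur would give a similar result on the core of compound 1, which has so far been seen only with other groups there.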